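The compounds below may be only part of what the source reports. "The series", "measured", "known", "first", "only" and "open" are said of these compounds alone.

Measured compounds:
compound 1 `O=C(Nc1ccc(-n2ncc3c(F)cccc32)cc1)Nc1ccc(Cl)c(C(F)(F)F)c1` — 9800 nM
compound 2 `O=C(Nc1ccc(-n2ncc3ccccc32)cc1)Nc1ccc(Cl)c(C(F)(F)F)c1` — 8700 nM

Compound 2 gives the lowest of the two numbers in a functional assay on LoVo cells (Homo sapiens) for cytotoxicity, read by MTT assay, with a stated time of 72 h (on this read-out higher numbers stand for weaker inhibition and lower numbers for stronger inhibition), and its nearest neighbour is compound 1, which in this assay gives 9800 nM; the two are within the scatter of one another, so no order between them can be claimed.

Compound 3 `CNc1cccc2c1cnn2-c1ccc(NC(=O)Nc2ccc(Cl)c(C(F)(F)F)c2)cc1` is not yet measured in this assay. It departs from compound 2 by methylamino in place of hydrogen on an aromatic carbon.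

Within the data shown here, only one measured step is available to bear on this change: a 1.1-fold lower number from compound 1 to compound 2 (0.05 log units; within the scatter). That step also exchanged a substituent on an aromatic carbon of the shared core for hydrogen and left the read-out unchanged beyond the scatter. Among the measured compounds shown here, no measured step introduces methylamino or any group with a hydrogen-bond donor on that ring, so the present change is not directly covered, and the expectation rests on the flatness of the one step seen.

On that basis, the step from compound 2 to compound 3 is expected to be a 1.0-fold higher number from compound 2 to compound 3 (0.01 log units; within the scatter), with no change beyond the scatter anticipated. Compound 3 is therefore estimated at 9000 nM in this assay, within a range from 3000 nM to 27000 nM.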

Compound 3, half-maximal inhibitory concentration: 6300 nM
Beside the measured number, compound 3's estimate is 1.4-fold (0.15 log units) above it; the measured number falls inside the stated range.
By their numbers in this assay, from the lowest: compounds 3, 2 and 1 (each within the scatter of the next).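

In this assay this aromatic carbon of the shared core, ortho to a fused ring and meta to a fused ring, takes methylamino, which brings a hydrogen-bond donor and a hydrogen-bond acceptor, and the read-out stays within the scatter (a 1.4-fold lower number from compound 2 to compound 3 (0.14 log units; within the scatter)). The same holds when methylamino is set against fluoro at this carbon (a 1.6-fold lower number from compound 1 to compound 3 (0.19 log units; within the scatter)), so hydrogen, fluoro and methylamino cannot be told apart here, and the earlier single step between hydrogen and fluoro now extends to a group with heavy atoms beyond one and with a hydrogen-bond donor. No supporting evidence is available that bears on this result.

The compounds shown leave open whether this flat response persists for an unsubstituted amine, a dimethylamino group, a carboxylic acid or a longer chain such as butylamino at this carbon. They also leave open whether any group here can move the read-out beyond the scatter, and whether the same holds at the other aromatic carbons of this ring.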